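Geometric isomers of a furoic acid in a cytotoxicity assay

The source may report more compounds than this note shows. Statements on the series, on what has been measured and on what is new or still open speak of the compounds shown alone.

Measured compounds:
compound 1, `C=C/C(C)=C/CC/C(C)=C/c1cc(C(=O)O)co1`: 80400 nM
compound 2, `C=C/C(C)=C\CC/C(C)=C/c1cc(C(=O)Nc2ccc(C)cc2)co1`: 59500 nM
compound 3, `C=C/C(C)=C\CC/C(C)=C/c1cc(C(=O)N2CCN(C(c3ccccc3)c3ccccc3)CC2)co1`: 28500 nM

Of the compounds shown here, three sharing a substituted furan core have been tested in a functional assay on HeLa cells (Homo sapiens) for cytotoxicity, read by MTT assay, with a stated time of 48 h; a higher number here means a weaker inhibitor, a lower number a stronger inhibitor. Compound 1, the free carboxylic acid, gives 80400 nM, the highest number of the three. Compound 2, an anilide, gives 59500 nM, which lies within the scatter of the value for compound 1, so the two cannot be ranked. Compound 3, a piperazine amide, gives 28500 nM, and its gap to compound 1 lies beyond the scatter.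

The step considered here leads from compound 1 to compound 4, `C=C/C(C)=C\CC/C(C)=C/c1cc(C(=O)O)co1`, which has not yet been measured. The change is the two compounds have the same atoms and bonds and differ only in configuration as drawn: 1 of 2 stereo elements differ; a double bond is drawn E in compound 1 and Z in compound 4. For the measured compounds named here, no measured pair in this set differs only in configuration, so there is no direct precedent for a step of this kind. One double bond drawn differently in a side chain, with everything else unchanged, is expected to move the number in this assay little, if at all beyond the scatter, and in no particular direction. Compound 4 is therefore estimated at 75000 nM, within 35000 nM to 160000 nM, the expected step being a 1.1-fold lower number from compound 1 to compound 4 (0.03 log units; within the scatter).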

Compound 4, half-maximal inhibitory concentration: 81000 nM
Estimate against measurement, compound 4: 1.1-fold (0.03 log units) below, within the range that was stated.
By their numbers in this assay, from the lowest: compound 3; then compounds 2, 1 and 4 (each within the scatter of the next).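

In this assay, the double bond drawn E in compound 1 and Z in compound 4 makes no difference that can be read, with a 1.0-fold higher number from compound 1 to compound 4 (0.00 log units; within the scatter). For the compounds shown here, this is the first pair in the set to isolate configuration, so the reading concerns that double bond alone: the fact that compounds 1 and 4 differ only in the configuration as drawn. With the Z form held fixed, placing hydroxy instead of (4-methylphenyl)amino on the carbonyl carbon also gives no separation, with a 1.4-fold higher number from compound 2 to compound 4 (0.13 log units; within the scatter), so compound 2 and compound 4 cannot be ranked.

Still open, on these data alone, is whether configuration at this double bond matters when an amide replaces the acid, as in compound 2 and compound 3, or whether the second double bond, drawn alike throughout, affects the number. Also open, as far as these compounds go, is how a methyl ester or a primary amide on the carbonyl carbon would compare with the acid.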